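Chain length in the ynone series against sphingosine kinase 1

This account rests on a few compounds, and the source may have more. Where it says the series, first, only, none or still open, it means among the compounds named here.

Measured so far:
- compound 1 `CCCCC#CC(=O)[C@@H]1COC(C)(C)N1C(=O)OC(C)(C)C`: 9.08%
- compound 2 `CCCCCCCCC#CC(=O)[C@@H]1COC(C)(C)N1C(=O)OC(C)(C)C`: 15.2%
- compound 3 `CCCCC#C[C@H](O)[C@H](CO)NC(=O)OC(C)(C)C`: "not active" (no number reported)

Among the measured compounds shown here, in an assay on CHO cells for inhibition of sphingosine kinase 1 (Homo sapiens), tested at 10 uM (on this read-out higher numbers stand for more inhibition at the one concentration tested (going by the name of the read-out) and lower numbers for less inhibition), compound 2 gives 15.2%, the higher of the two numbers recorded, with compound 1 nearest at 9.08%; the one step between them, a number 6.1 percentage points higher from compound 1 to compound 2 (within the scatter), lies within the scatter, so no order between them is claimed. Compound 3 is reported in this assay as "not active" (no number reported) without a number.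

Compound 4 `CCCCCCCCCCCCCC#CC(=O)[C@@H]1COC(C)(C)N1C(=O)OC(C)(C)C` differs from compound 2 by pentyl in place of hydrogen on a saturated chain carbon, eight bonds along the chain from a triple-bonded carbon. For the measured compounds named here, the only measured step that bears on this, a number 6.1 percentage points higher from compound 1 to compound 2 (within the scatter), is of the same kind, a lengthening of the same chain, and was within the scatter. The expected step is therefore small and, if anything, upward: a number 4.8 percentage points higher from compound 2 to compound 4 (within the scatter) is estimated, not beyond the scatter. Compound 4 is expected to give 20% in this assay, in the range 5% to 40%.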

Compound 4, a percentage reported as inhibition, at one concentration (the size of the read-out at that concentration, not a potency): 54.7%
For compound 4 the middle estimate is 34.7 percentage points below the measured one; the whole stated range lies below it.
By their numbers in this assay, from the lowest: compounds 1 and 2 (each within the scatter of the next); then compound 4.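

In this assay, among the compounds shown here, the position eight bonds along the chain from a triple-bonded carbon responds clearly to pentyl in place of hydrogen, with a number 39.5 percentage points higher from compound 2 to compound 4 (beyond the scatter) and thus the first change that stands out from the scatter. Nonyl in place of hydrogen, four bonds along the chain from a triple-bonded carbon, gives a number 45.6 percentage points higher from compound 1 to compound 4 (beyond the scatter) while butyl at that place gave only a number 6.1 percentage points higher from compound 1 to compound 2 (within the scatter) so among these three compounds, the separation appears only with the longest chain. No measurement here accounts for this separation.

As far as these compounds go, whether a longer chain than that of compound 4 raises the inhibition further or loses it remains open, since three chain lengths fix no trend. Also open, from the compounds shown here alone, is whether an amine or a carboxylic acid in place of the pentyl would keep the inhibition.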